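The source may report more compounds than this note shows. Statements on the series, on what has been measured and on what is new or still open speak of the compounds shown alone.

For the measured compounds named here, compound 2, whose structure is `CCN1CCc2c(c(C(C)(C)C)nn2C(=O)Nc2ccc(F)cc2F)C1`, stands highest of the two compounds measured so far in a functional assay on the whole organism (strain Swiss albino) for inhibition, with Mus musculus as the target, in the formalin test, with a stated time of 30 min, at a dose of 100 mg/kg (a higher number here means more inhibition at the dose given (going by the name of the read-out), a lower number less inhibition), where compound 2 gives 73.4%. Going by the values given here, its only neighbour, compound 1 with structure `CCN1CCc2c(c(C(C)(C)C)nn2C(=O)Nc2ccc(C)cc2C)C1`, gives 59.9% in this assay, and the step of a number 13.5 percentage points higher from compound 1 to compound 2 (beyond the scatter) is the one measured difference available, arising from 2,4-difluorophenyl in place of 2,4-dimethylphenyl on the amide-type nitrogen. Compound 3, with structure `CCN1CCc2c(c(C(C)(C)C)nn2C(=O)Nc2ccc(Cl)cc2)C1`, differs from compound 2 in the same region: 4-chlorophenyl in place of 2,4-difluorophenyl on an amide-type nitrogen. The measured step bears only loosely on this change, since it exchanged one pair of ring substituents for another pair, whereas here a pair of fluorines gives way to a single chlorine. Among the compounds with values here, with no closer precedent, the expected step of a number 8.4 percentage points lower from compound 2 to compound 3 (within the scatter) is one that stays within the scatter or is modestly downward, because the halogenated aryl of compound 2 already gave 73.4%. Compound 3 is therefore estimated at 65% in this assay, within a range from 48% to 80%.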

Compound 3, a percentage reported as inhibition, in the whole organism at one dose (the size of the read-out at that dose, not a potency): 68.3%
Compound 3: middle estimate off by 3.3 percentage points, on the low side; low and high end bracket the measured number.
By their numbers in this assay, from the lowest: compounds 1, 3 and 2 (each within the scatter of the next, the first and the last beyond it).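

In this assay, 4-chlorophenyl on the amide-type nitrogen gives a number 5.1 percentage points lower from compound 2 to compound 3 (within the scatter) and, set against the dimethyl-substituted ring, a number 8.4 percentage points higher from compound 1 to compound 3 (within the scatter). A ring carrying one chlorine therefore cannot be told apart from either the 2,4-difluorophenyl or the 2,4-dimethylphenyl ring at this position, although those two remain separated beyond the scatter. The earlier contrast between the two disubstituted rings thus does not divide the three compounds into two clear groups, and nothing available explains these numbers.

The change from compound 2 to compound 3 alters both the halogen and the substitution pattern of the ring at once, so the contribution of each remains unresolved, and 4-fluorophenyl or 2-chlorophenyl on the same nitrogen would be needed to separate them. Also open, on these data alone, is whether this position needs an aromatic ring at all, a question that a pyridyl or a cyclohexyl group in its place could address, and each of these readings rests on a single dose rather than on a potency.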